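Ether-linked bicyclic heteroaryl swaps on a shared anilinoquinazoline-type core

The source may hold more compounds than are shown below. What is called first, only, known or untested is meant among the compounds shown, and "the series" means these compounds.

Working notes on the series. Three compounds share one core and differ only in the bicyclic group on the ether oxygen: compound 1 `Cc1cc(Nc2ncnc3cc(O)c(NC(=O)/C=C/[C@H]4CCCN4C)cc23)ccc1Oc1ccn2ccnc2c1`, compound 2 `Cc1cc(Nc2ncnc3cc(O)c(NC(=O)/C=C/[C@H]4CCCN4C)cc23)ccc1Oc1ccc2nccn2c1` and compound 3 `Cc1cc(Nc2ncnc3cc(O)c(NC(=O)/C=C/[C@H]4CCCN4C)cc23)ccc1Oc1cnc2ccnn2c1`. In a functional assay on NCI-N87 cells (Homo sapiens) for inhibition, read by CellTiter-Glo, with a stated time of 72 h (a higher number here means a weaker inhibitor, a lower number a stronger inhibitor), compound 1 gives 4.55 nM, compound 2 gives 4.08 nM and compound 3 gives 1.9 nM, the lowest of the three numbers. The step of a 1.1-fold lower number from compound 1 to compound 2 (0.05 log units; within the scatter) shows that one bicycle swap is within the scatter, while a 2.4-fold lower number from compound 1 to compound 3 (0.38 log units; beyond the scatter) and a 2.1-fold lower number from compound 2 to compound 3 (0.33 log units; beyond the scatter) are modest steps beyond it.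

Compound 4 `Cc1cc(Nc2ncnc3cc(O)c(NC(=O)/C=C/[C@H]4CCCN4C)cc23)ccc1Oc1ccn2cnnc2c1` is not yet measured; against compound 3 the change is a group of 9 heavy atoms (6 carbon, 3 nitrogen; one five-membered aromatic ring with 3 hetero atoms, one six-membered aromatic ring with 1 hetero atom) in place of a group of 9 heavy atoms (6 carbon, 3 nitrogen; one five-membered aromatic ring with 2 hetero atoms, one six-membered aromatic ring with 2 hetero atoms), on an oxygen on an aromatic ring. The three measured steps bear on it as further bicycle swaps on the same oxygen and span within-scatter to modest size. A step of that order in either direction is therefore expected in this assay, most likely a small rise in the number since compound 3 is already the lowest. For compound 4 the estimate is 3 nM, range 1.5 nM to 7 nM, meaning an expected step of a 1.6-fold higher number from compound 3 to compound 4 (0.20 log units; within the scatter).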

Compound 4, half-maximal inhibitory concentration: 32.9 nM
Beside the measured number, compound 4's estimate is 11-fold (1.04 log units) below it; the measured number lies above the stated range.
By their numbers in this assay, from the lowest: compound 3; then compounds 2 and 1 (each within the scatter of the next); then compound 4.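

In this assay the group on the ether oxygen proves far more sensitive than the earlier swaps showed: a 17-fold higher number from compound 3 to compound 4 (1.24 log units; beyond the scatter) is a large step, although the two groups hold the same atoms and the same counts of hydrogen-bond donors and acceptors, and differ only in how those atoms are joined. The rise is not confined to the comparison with the lowest number, as an 8.1-fold higher number from compound 2 to compound 4 (0.91 log units; beyond the scatter) and a 7.2-fold higher number from compound 1 to compound 4 (0.86 log units; beyond the scatter) also lie beyond the scatter, and the group in compound 4 is the only one here with three hetero atoms in its five-membered aromatic ring. No measurement given here accounts for the step.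

On these data alone, whether a methyl or an amine on that five-membered ring would move the number in this assay remains open. The four compounds also leave open whether other arrangements of these atoms behave like compound 4 or like compound 3.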